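Phenyl substituent swap in a tetrazolyl-acetamide series

This account rests on a few compounds, and the source may have more. Where it says the series, first, only, none or still open, it means among the compounds named here.

Working notes on a set of tetrazolyl-acetamides sharing one core. Compound 1 `Cc1cc(NC(=O)Cn2nnc(-c3ccccc3)n2)n(C2CCS(=O)(=O)C2)n1` gives 93% in an assay on HEK293 cells for activation of Kir3.1/Kir3.2 (Homo sapiens), read by thallium flux; on this read-out lower numbers stand for smaller maximal responses and higher numbers for larger maximal responses. Compound 2 `CC1CC1c1cc(NC(=O)Cn2nnc(-c3ccccc3)n2)n(C2CCCCC2)n1` gives 78% in this assay. Compound 3 `Cc1cc(NC(=O)Cn2nnc(-c3ccc(F)cc3)n2)n(C2CCCCC2)n1` gives 92% in this assay. Among these three numbers compound 3 and compound 1 lie within the scatter of one another, so no order is read between them, whereas compound 2 stands lower than compound 3 by a margin beyond the scatter.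

Compound 4 `Cc1cc(NC(=O)Cn2nnc(-c3cccc(C#N)c3)n2)n(C2CCCCC2)n1` has not been run in this assay. It differs from compound 3 only at the aromatic carbon of the tetrazole: 3-cyanophenyl in place of 4-fluorophenyl on an aromatic carbon. For the measured compounds named here, no measured pair in the set isolates this change, so there is no step to lean on. The measured values of compound 1, compound 2 and compound 3 all sit in a fairly narrow band, and nothing here argues for a move beyond the scatter in either direction. Compound 4 is therefore expected to give about 86% in this assay, within a range of 66% to 102%. The step of a number 6 percentage points lower from compound 3 to compound 4 (within the scatter) is estimated as small and within the scatter.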

Compound 4, largest response reached (Emax), in percent of the reference or control that the assay uses: 80%
Compound 4: the middle estimate sits 6 percentage points above what was measured; low and high end bracket the measured number.
By their numbers in this assay, from the lowest: compounds 2 and 4 (each within the scatter of the next); then compounds 3 and 1 (each within the scatter of the next).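

In this assay, putting 3-cyanophenyl in place of 4-fluorophenyl on the aromatic carbon of the five-membered aromatic ring with 4 nitrogen gives a number 12 percentage points lower from compound 3 to compound 4 (beyond the scatter) with the rest of the structure unchanged. For the compounds shown here, this is the first single-place step in the set, and it shows that the maximal response can shift beyond the scatter through the aryl group at this position alone. No measurement at hand accounts for the step.

The change swaps both the substituent and where it sits on the phenyl ring, so the compounds shown leave open how much of the step belongs to each; 4-cyanophenyl and 3-fluorophenyl would separate the two. Also open, on these data alone, is how this position behaves with a carboxylic acid or an amine on the phenyl ring.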